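The compounds below may be only part of what the source reports. "The series", "measured", "known", "first", "only" and "open" are said of these compounds alone.

Measured compounds:
- compound 1 `CC(C)=CCC1Cc2c(OC(=O)Nc3ccc(F)c(F)c3)cc(=O)n(CCCO)c2CC1(C)C`: 0%
- compound 2 `CC(C)=CCC1Cc2c(OC(=O)Nc3ccc(Cl)cc3)cc(=O)n(CCCO)c2CC1(C)C`: 0%
- compound 3 `CC(C)=CCC1Cc2c(OC(=O)Nc3cccc(C(F)(F)F)c3)cc(=O)n(CCCO)c2CC1(C)C`: 0%

In a functional assay on PANC-1 cells (Homo sapiens) for inhibition, read by MTT assay, with a stated time of 24 h, tested at 10 uM (on this read-out higher numbers stand for more inhibition at the one concentration tested (going by the name of the read-out) and lower numbers for less inhibition), compound 1 gives 0%, compound 2 gives 0%, and compound 3 gives 0%. Compound 3 therefore stands level with compounds 1 and 2 in this assay; none of the three shows any inhibition at the concentration tested. The steps among them, no change at the digits printed from compound 1 to compound 2 (within the scatter), no change at the digits printed from compound 1 to compound 3 (within the scatter) and no change at the digits printed from compound 2 to compound 3 (within the scatter), all lie within the scatter, so exchanging one aryl group on the amide-type nitrogen for another has made no difference so far.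

Compound 4 `CC(C)=CCC1Cc2c(OC(=O)Nc3ccc(Cl)c(Cl)c3)cc(=O)n(CCCO)c2CC1(C)C` is the next member of the series. It differs from compound 3 in one place: 3,4-dichlorophenyl in place of 3-(trifluoromethyl)phenyl on an amide-type nitrogen. All three measured steps bear on this change, since each of them swaps a substituted phenyl on the same amide-type nitrogen, and each was flat. Compound 4 is therefore expected to show no step beyond the scatter, no change at the digits printed from compound 3 to compound 4 (within the scatter), in this assay. The estimated value for compound 4 is 0%, with a range from 0% to 10%.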

Compound 4, a percentage reported as inhibition, at one concentration (the size of the read-out at that concentration, not a potency): 1.8%
For compound 4 the middle estimate is 1.8 percentage points below the measured one; measured number inside the range.
By their numbers in this assay, from the lowest: compounds 1, 2, 3 and 4 (each within the scatter of the next).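

In this assay, 3,4-dichlorophenyl on the amide-type nitrogen gives a number 1.8 percentage points higher from compound 3 to compound 4 (within the scatter) and, set against 3,4-difluorophenyl, a number 1.8 percentage points higher from compound 1 to compound 4 (within the scatter), so a fourth substituted phenyl also leaves this position without a step beyond the scatter. The smaller edit of chloro in place of hydrogen on an aromatic carbon, unlike the earlier exchanges of one substitution pattern for another, shows a number 1.8 percentage points higher from compound 2 to compound 4 (within the scatter), so adding this one chloro does not separate the compounds either. No evidence on hand bears on this result.

Still open, as far as these compounds go, is whether a basic amine or a carboxylic acid on the phenyl ring would read differently in this assay. Equally open, from the compounds shown here alone, is whether a benzyl, cyclohexyl or pyridyl group on that nitrogen, in place of a substituted phenyl, would give a step beyond the scatter.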